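This account rests on a few compounds, and the source may have more. Where it says the series, first, only, none or still open, it means among the compounds named here.

Measured compounds:
Compound 1, `Oc1cccc(-c2cc(-c3cccc(F)c3)cc(-c3ccccc3O)n2)c1`. In a functional assay on HCT-15 cells (Homo sapiens) for inhibition (on this read-out lower numbers stand for stronger inhibition and higher numbers for weaker inhibition), compound 1 gives > 50000 nM, which is a limit of the assay rather than a number.
Compound 2, `Oc1ccc(-c2cc(-c3cccc(F)c3)cc(-c3ccccc3O)n2)cc1`. In this assay compound 2 gives > 50000 nM, again a limit of the assay.
Compound 3, `Oc1cccc(-c2cc(-c3ccccc3OC(F)(F)F)cc(-c3cccc(O)c3)n2)c1`. In this assay compound 3 gives 4220 nM.

Compound 4, `Oc1ccc(-c2cc(-c3ccccc3OC(F)(F)F)cc(-c3cccc(O)c3)n2)cc1`, has not yet been measured. It differs from compound 3 by 4-hydroxyphenyl in place of 3-hydroxyphenyl on an aromatic carbon. The same kind of change, (4-hydroxyphenyl in place of 3-hydroxyphenyl on an aromatic carbon), links compound 1 and compound 2, where the step is a step that the two limits leave unreadable from compound 1 to compound 2 because of the limit of > 50000 nM in this assay, at which 2 of the 3 values shown sit. The difference between the two cores is not broken down here. The surroundings of the change also differ: in compound 1 the place is meta to a 2-hydroxyphenyl group and meta to a 3-fluorophenyl group, in compound 3 it is meta to a 3-hydroxyphenyl group and meta to a large group. Going by the values given here, the earlier step gives no readable size, so the expected step is a 1.4-fold higher number from compound 3 to compound 4 (0.15 log units; within the scatter), an estimate resting on compound 3 at 4220 nM as the only number available. Compound 4 is estimated at 6000 nM, expected to lie between 1500 nM and 40000 nM.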

Compound 4, half-maximal inhibitory concentration: 2310 nM
Compound 4: middle estimate off by 2.6-fold (0.41 log units), on the high side, and the stated range covers the measured number.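

In this assay, 4-hydroxyphenyl in place of 3-hydroxyphenyl gives a 1.8-fold lower number from compound 3 to compound 4 (0.26 log units; within the scatter), so on this core the two compounds cannot be told apart. The same change on the core of compound 1 cannot be read, because compound 1 and compound 2 both give only a limit of the assay, not a number: the limit of > 50000 nM in this assay, at which 2 of the 4 values shown sit. The series therefore offers a single readable step and does not show whether the result carries over from one core to the other.

Still open, as far as these compounds go, is how a phenyl ring carrying an amine or a carboxylic acid instead of the hydroxy group would behave at this place. Also open, from the compounds shown here alone, is whether any such group would separate the two positions in this assay.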